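Thiazole and thienothiazole series: pyrrolidinyl for methylsulfanyl

The compounds below may be only part of what the source reports. "The series", "measured", "known", "first", "only" and "open" are said of these compounds alone.

Measured so far:
compound 1 `CSc1nc(Cl)c(C(=O)c2ccccc2)s1` — in a functional assay on U-373MG ATCC cells (Homo sapiens) for cytotoxicity, read by MTT assay, with a stated time of 72 h (on this read-out lower numbers stand for stronger inhibition and higher numbers for weaker inhibition), compound 1 gives > 100000 nM
compound 2 `O=C(c1ccccc1)c1sc(N2CCCC2)nc1Cl` — in this assay compound 2 gives 82000 nM
compound 3 `COC(=O)c1sc2nc(SC)sc2c1C` — in this assay compound 3 gives 92000 nM

The value for compound 1 is a limit of this assay, not a number (the limit of > 100000 nM in this assay, at which 1 of the 3 values shown sits). From compound 1 to compound 2 the change is pyrrolidin-1-yl in place of methylsulfanyl on an aromatic carbon, and the step is an at least 1.2-fold lower number from compound 1 to compound 2 (0.08 log units; that floor lies within the scatter); its floor lies within the scatter, so the step tells little. Compound 3 and compound 2 lie within the scatter of each other. The difference between the core of compound 3 and that of compound 1 is not broken down here.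

Compound 4 `COC(=O)c1sc2nc(N3CCCC3)sc2c1C` is not yet measured. It differs from compound 3 by pyrrolidin-1-yl in place of methylsulfanyl on an aromatic carbon, the same kind of change as that from compound 1 to compound 2, but here the place is part of a fused or bridged system of two rings, whereas in compound 1 the place is two ring bonds from the ring atom that bears a chloro group and two ring bonds from the ring atom that bears a group of 8 heavy atoms. Since the earlier step of an at least 1.2-fold lower number from compound 1 to compound 2 (0.08 log units; that floor lies within the scatter) is bounded only by a floor within the scatter, the expected step for compound 4 is a 1.2-fold lower number from compound 3 to compound 4 (0.06 log units; within the scatter), resting on compound 3 at 92000 nM. Compound 4 is estimated at 80000 nM, between 40000 nM and 160000 nM.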

Compound 4, half-maximal inhibitory concentration: 89000 nM
Beside the measured number, compound 4's estimate is 1.1-fold (0.05 log units) below it, and the stated range covers the measured number.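

In this assay, pyrrolidin-1-yl in place of methylsulfanyl on an aromatic carbon gives a 1.0-fold lower number from compound 3 to compound 4 (0.01 log units; within the scatter). Set beside the same change on the other core, the comparison reads: the same change on two cores in this assay, an at least 1.2-fold lower number (0.08 log units; that floor lies within the scatter) from compound 1 to compound 2 and a 1.0-fold lower number (0.01 log units; within the scatter) from compound 3 to compound 4; the limit leaves it open whether they differ

Compound 1 gives > 100000 nM, a limit and not a number, so the size of the change cannot be shown to carry from one core to the other, and only the step on the fused core is fully read.

The compounds shown carry only methylsulfanyl or pyrrolidin-1-yl at this place, which leaves open whether any other group there would move the number. A morpholine or a primary amine at this place remains untested in the compounds shown, as does a carboxylic acid in place of the methyl ester.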